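The compounds below may be only part of what the source reports. "The series", "measured", "known", "first", "only" and "open" are said of these compounds alone.

Of the compounds shown here, three of one shared core have been measured in a functional assay on MDA-MB-231 cells (Homo sapiens) for inhibition, read by MTT assay, with a stated time of 48 h; on this read-out lower numbers stand for stronger inhibition of growth and higher numbers for weaker inhibition of growth. Compound 1 `CC(C)c1ccc(Nc2ncnc3ccc(NC(=S)NCc4ccccc4)cc23)cc1` gives 12800 nM in this assay. Compound 2 `NS(=O)(=O)c1ccc(Nc2ncnc3ccc(NC(=S)NCc4ccccc4)cc23)cc1` reaches only the limit of this assay, > 30000 nM, and no number. Compound 3 `S=C(Nc1ccccc1)Nc1ccc2ncnc(Nc3cccc(Br)c3)c2c1` gives 10000 nM in this assay; its number sits within the scatter of that of compound 1, so no order between the two can be read.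

Going by the values given here, the one measured step, an at least 2.3-fold higher number from compound 1 to compound 2 (0.36 log units; beyond the scatter), changes the aryl group on the amine attached to the shared core, and it touches the limit of > 30000 nM in this assay, at which 1 of the 3 values shown sits, rather than a full number.

Compound 4 `S=C(Nc1cc(Cl)cc(Cl)c1)Nc1ccc2ncnc(Nc3cccc(Br)c3)c2c1` differs from compound 3 in a different place: 3,5-dichlorophenyl in place of phenyl on an amide-type nitrogen. Among the compounds with values here, no measured step in this assay exchanges a group on the thiourea nitrogen, so nothing measured bears directly on this change, and no step beyond the scatter can be expected with confidence in this assay. Compound 4 is therefore estimated at 7000 nM, with a range from 2500 nM to 25000 nM. That estimate means an expected step of a 1.4-fold lower number from compound 3 to compound 4 (0.15 log units; within the scatter), within or near the usual scatter.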

Compound 4, concentration for 50% growth inhibition: 3000 nM
Compound 4: middle estimate off by 2.3-fold (0.37 log units), on the high side, and the stated range covers the measured number.
By their numbers in this assay, from the lowest: compound 4; then compounds 3 and 1 (each within the scatter of the next). At a limit, above all of these: compound 2.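

In this assay, going by these compounds alone, the step of a 3.3-fold lower number from compound 3 to compound 4 (0.52 log units; beyond the scatter) is the first measured change on the amide-type nitrogen whose other neighbour is the thiocarbonyl carbon. It shows that this end of the molecule can also move the number beyond the scatter, whereas the earlier measured step changed only the aryl group on the amine attached to the shared core. Here the ring stays a six-membered aromatic ring of carbon and gains two chlorine atoms, with a lower number standing for stronger inhibition of growth, but nothing measured here explains why this exchange lowers the number.

The compounds shown leave open whether both chlorine atoms are needed and whether other groups on this ring, such as a methoxy group, an amine or a carboxylic acid, would lower the number as well. This single pair also cannot show whether 3,5-dichlorophenyl would give a similar step on a compound carrying a different aryl group on the amine attached to the shared core, or whether it would replace the benzyl group of compound 1 with the same result.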